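The source may report more compounds than this note shows. Statements on the series, on what has been measured and on what is new or still open speak of the compounds shown alone.

In a functional assay on MCF7 cells (Homo sapiens) for inhibition, read by MTT assay, with a stated time of 48 h (a higher number here means a weaker inhibitor, a lower number a stronger inhibitor), compound 1 `CC(=O)c1ccc(Nc2c(C(C)=O)sc(NC(=O)CC#N)c2C#N)cc1` gives 41400 nM, and compound 2 `CC(=O)c1ccc(Nc2c(C(=O)/C=C/c3ccccc3)sc(/N=C/c3ccccc3)c2C#N)cc1` gives 19100 nM. Going by the values given here, compound 1 therefore holds the higher of the only two numbers available, making it the weaker inhibitor of the pair, and the gap lies beyond the scatter. The next compound to be tested is compound 3 `CC(=O)Nc1sc(C(C)=O)c(Nc2ccc(C(C)=O)cc2)c1C#N`, which keeps the core of compound 1 but has hydrogen in place of cyano on a saturated chain carbon bound to a carbonyl carbon. Cut one bond further out, the same difference reads ((cyanomethyl)carbonyl)amino to acetamido.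

Among the compounds with values here, the series holds no measured pair that differs in one place, so there is no direct precedent for the size or direction of this change. The expectation therefore starts from compound 1 at 41400 nM and assumes no shift beyond the scatter in this assay. The estimated step of a 1.2-fold lower number from compound 1 to compound 3 (0.07 log units; within the scatter) is accordingly small. For compound 3, the expected value is 35000 nM, with an estimated range of 14000 nM to 85000 nM.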

Compound 3, half-maximal inhibitory concentration: 64600 nM
The estimate for compound 3 lay 1.8-fold (0.27 log units) below the measured number; the range from low to high includes it.
By their numbers in this assay, from the lowest: compound 2; then compounds 1 and 3 (each within the scatter of the next).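

The series now has its first comparison that differs in one place: in this assay, hydrogen in place of cyano on a saturated chain carbon bound to a carbonyl carbon gives a 1.6-fold higher number from compound 1 to compound 3 (0.19 log units; within the scatter). At this position, ((cyanomethyl)carbonyl)amino and acetamido are therefore not separated by this read-out, and the nitrile on the chain is not shown to matter for the number at this level of inhibition. No supporting data bear on this result.

Going by these compounds, whether the position is insensitive in general remains open, since only cyanomethyl and methyl are compared here; an amine or a carboxylic acid on the same chain carbon, or a longer chain in place of the methyl of acetamido, could give a different reading. Compound 2 differs from both compound 1 and compound 3 in more than one place, so it gives no reading on this position, and whether the same change would read alike on a different core is also unanswered.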